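The source may report more compounds than this note shows. Statements on the series, on what has been measured and on what is new or still open speak of the compounds shown alone.

Within the data shown here, in a functional assay on cells (Mast cell, Rattus norvegicus, strain Wistar) for activation, read by fluorescence, with a stated time of 15 min (a higher number here means that more compound is needed for the effect, a lower number that less compound is needed), compound 1 (`CCCCCCCCCCCCCCCCCC(=O)OCCCOP(=O)(O)OC[C@H](N)C(=O)O`) gives 500 nM, the lower of the two numbers so far. Compound 2 (`CCCCCCCCCCCCCCCCCC(=O)CCCCOP(=O)(O)OC[C@H](N)C(=O)O`) gives 5000 nM, a gap beyond the scatter. Compound 3 (`CCCCCCCCCCCCCCCCCC(=O)OC[C@@H](COP(=O)(O)OC[C@H](N)C(=O)O)OC`) keeps the core of compound 1 with one change: methoxy in place of hydrogen on a saturated chain carbon bound to two saturated chain carbons. Among the measured compounds shown here, no measured pair differs in one place, so the data offer no direct precedent. The expected result in this assay is a 1.4-fold higher number from compound 1 to compound 3 (0.15 log units; within the scatter), slightly upward and not beyond the scatter. For compound 3 the estimate is 700 nM, with an expected range of 150 nM to 3500 nM.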

Compound 3, half-maximal effective concentration: 5000 nM
Beside the measured number, compound 3's estimate is 7.1-fold (0.85 log units) below it, and the stated range ends below it.
By their numbers in this assay, from the lowest: compound 1; then compounds 2 and 3 (each within the scatter of the next).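

In this assay, among these compounds, the single change of methoxy in place of hydrogen, on a saturated chain carbon bound to two saturated chain carbons, gives a 10-fold higher number from compound 1 to compound 3 (1.00 log units; beyond the scatter) and so is not tolerated without cost at this position. Among the compounds shown here, this is the first step that can be read at one place, and it shows that this carbon affects the number. Nothing in hand explains the rise. As far as these compounds go, whether a hydroxyl or an ethoxy on this carbon would stay closer to compound 1 remains open.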